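Ether side-chain variation in an oxabicyclic prostanoid series

A few compounds are considered here, and "the series" means these few. Any claim that something is new, unique, unknown or untested is made for them only; others in the source may bear on it.

Measured so far in a functional assay (plasma) for inhibition, with Homo sapiens as the target; a higher number here means a weaker inhibitor, a lower number a stronger inhibitor:
compound 1 `O=C(O)CCC/C=C\CC1C2CCC(O2)C1COCC1CCCCC1` gives 165000 nM
compound 2 `COCC1C2CCC(O2)C1C/C=C\CCCC(=O)O` gives 22000 nM

Compound 1 has the highest of the two numbers; the nearest is compound 2, reached by a 7.5-fold lower number from compound 1 to compound 2 (0.88 log units; beyond the scatter), which is described as hydrogen in place of cyclohexyl on a saturated chain carbon bound to an oxygen on a saturated carbon. Compound 3 `CCCCCOCCC1C2CCC(O2)C1C/C=C\CCCC(=O)O` differs from compound 1 by (pentyloxy)methyl in place of cyclohexylmethoxy on a saturated chain carbon bound to a saturated ring carbon. For the measured compounds named here, the only step that bears on this is a 7.5-fold lower number from compound 1 to compound 2 (0.88 log units; beyond the scatter), where losing the ring lowered the number modestly. Compound 3 also loses the ring but keeps a chain of similar count, so a smaller step in the same direction is expected, a 2.8-fold lower number from compound 1 to compound 3 (0.44 log units; beyond the scatter). Compound 3 is therefore estimated at 60000 nM, within 20000 nM to 180000 nM.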

Compound 3, half-maximal inhibitory concentration: 105000 nM
Estimate against measurement, compound 3: 1.8-fold (0.24 log units) below, and the stated range covers the measured number.
By their numbers in this assay, from the lowest: compound 2; then compounds 3 and 1 (each within the scatter of the next).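

In this assay, (pentyloxy)methyl in place of cyclohexylmethoxy gives a 1.6-fold lower number from compound 1 to compound 3 (0.20 log units; within the scatter), so at this position the open chain and the ring-bearing group read alike. (Pentyloxy)methyl in place of methoxy gives a 4.8-fold higher number from compound 2 to compound 3 (0.68 log units; beyond the scatter), so the lower number of compound 2 goes with methoxy and not simply with the absence of the ring. Nothing available gives a cause for either step.

Still open, from the compounds shown here alone, is how the number runs with a propoxy group, which would lie in length between methoxy and pentyloxy. An amine at the end of the ether chain is also untested in the compounds shown.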